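The source may hold more compounds than are shown below. What is called first, only, known or untested is meant among the compounds shown, and "the series" means these compounds.

Measured compounds: compound 1 `CN(C)CCn1cnnc1-c1cc(Oc2ccc(NC(=O)N/N=C/c3cc(C(C)(C)C)cc(C(C)(C)C)c3O)cc2F)ccn1`, 680 nM; compound 2 `COc1cc(/C=N/NC(=O)Nc2ccc(Oc3ccnc(-c4nncn4CCN(C)C)c3)c(F)c2)cc(OC)c1OC`, 3620 nM; compound 3 `CN(C)CCn1cnnc1-c1cc(Oc2ccc(NC(=O)N/N=C/c3cc(Br)c(O)c(Br)c3)cc2F)ccn1`, 2670 nM.

In a functional assay on HT-29 cells (Homo sapiens) for cytotoxicity, read by MTT assay, with a stated time of 72 h (a higher number here means a weaker inhibitor, a lower number a stronger inhibitor), compound 2 gives the highest of the three numbers. Its nearest neighbour is compound 3, and a 1.4-fold lower number from compound 2 to compound 3 (0.13 log units; within the scatter); compound 1 gives a lower number, beyond the scatter. Compound 4 `CN(C)CCn1cnnc1-c1cc(Oc2ccc(NC(=O)N/N=C/c3cccc(O)c3)cc2F)ccn1` differs from compound 2 by 3-hydroxyphenyl in place of 3,4,5-trimethoxyphenyl on a carbon with a double bond to nitrogen. Going by the values given here, the only measured step at that position is the one from compound 2 to compound 3, and it lies within the scatter, so the data offer no firm direction. Compound 4 is therefore expected to stay near compound 2, with a 1.0-fold higher number from compound 2 to compound 4 (0.02 log units; within the scatter). The estimate for compound 4 is 3800 nM, within a range of 1500 nM to 10000 nM.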

Compound 4, half-maximal inhibitory concentration: 330 nM
Compound 4: the middle estimate sits 12-fold (1.06 log units) above what was measured; measured number outside the range, below it.
By their numbers in this assay, from the lowest: compound 4; then compound 1; then compounds 3 and 2 (each within the scatter of the next).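

In this assay, going by these compounds alone, the group on the carbon with a double bond to nitrogen turns out to matter: an 11-fold lower number from compound 2 to compound 4 (1.04 log units; beyond the scatter), and an 8.1-fold lower number from compound 3 to compound 4 (0.91 log units; beyond the scatter), whereas the only earlier step at this position stayed within the scatter. Both large drops come with 3-hydroxyphenyl entering, so the position can respond strongly to this change. From the compounds shown here alone, whether 3-methoxyphenyl or 3-aminophenyl at this position would keep the number as low remains open. No measurement shown here bears on why the number falls.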